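A few compounds are considered here, and "the series" means these few. Any claim that something is new, unique, unknown or untested is made for them only; others in the source may bear on it.

In an assay for inhibition of acid-sensing ion channel 3 (Homo sapiens), read by patch clamp, tested at 20 uM (on this read-out higher numbers stand for more inhibition at the one concentration tested (going by the name of the read-out) and lower numbers for less inhibition), compound 1 `C=CCNc1nc(N)c(C(=O)N=C(N)N)nc1Cl` gives 78%, and compound 2 `NC(N)=NC(=O)c1nc(Cl)c(NCC2CCCCC2)nc1N` gives 96%. Going by the values given here, the one measured step, a number 18 percentage points higher from compound 1 to compound 2 (beyond the scatter), came with a change at the same place on the shared core, a saturated chain carbon bound to a nitrogen on an aromatic ring. Among the compounds with values here, on the two numbers seen so far, compound 2 stands highest, with compound 1 as its only neighbour and that neighbour lower by a margin beyond the scatter.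

Compound 3 `NC(N)=NC(=O)c1nc(Cl)c(NCc2ccccc2F)nc1N` has not yet been measured in this assay. It differs from compound 2 in one place: 2-fluorophenyl in place of cyclohexyl on a saturated chain carbon bound to a nitrogen on an aromatic ring. Within the data shown here, the only step that bears on this change is the one from compound 1 to compound 2, which swapped a small group for a six-membered ring at the same position and gave a modest rise. Here one six-membered ring is exchanged for another, so the expected step of a number 8 percentage points lower from compound 2 to compound 3 (within the scatter) is small, and with compound 2 already near the top of the scale there is little room for a further rise. For compound 3 the estimated reading in this assay is 88%, in the range from 70% to 99%.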

Compound 3, a percentage reported as inhibition, at one concentration (the size of the read-out at that concentration, not a potency): 92%
For compound 3 the middle estimate is 4 percentage points below the measured one, and the stated range covers the measured number.
By their numbers in this assay, from the lowest: compound 1; then compounds 3 and 2 (each within the scatter of the next).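

In this assay, exchanging the one six-membered ring for the other gives a number 4 percentage points lower from compound 2 to compound 3 (within the scatter), so this read-out does not separate the aromatic ring from the non-aromatic one at this position. Each ring also compares in the same way with vinyl: one change gives a number 18 percentage points higher from compound 1 to compound 2 (beyond the scatter) and the other gives a number 14 percentage points higher from compound 1 to compound 3 (beyond the scatter), so among these three compounds, both six-membered rings read beyond the scatter relative to vinyl, and none of the three goes against this. Nothing measured here explains why the two rings read alike.

The compounds shown leave open what the fluorine adds, since none of them carries a plain phenyl, and whether a ring bearing an amine or a carboxylic acid, or a longer chain joining the ring to the nitrogen, would read the same way. A percentage at one concentration is also not a potency, so any real difference in potency that compound 2 and compound 3 may have remains unresolved.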